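The source may hold more compounds than are shown below. What is called first, only, known or untested is meant among the compounds shown, and "the series" means these compounds.

Values so far in a functional assay on SW-620 cells (Homo sapiens) for cytotoxicity, read by MTT assay, with a stated time of 72 h; a lower number here means a stronger inhibitor, a higher number a weaker inhibitor

- compound 1 `COc1cccc(/C=C2\CCC/C(=C\c3ccc(O)c(Cl)c3)C2=O)c1OC` gives 16800 nM
- compound 2 `COc1ccc(/C=C2\CCC/C(=C\c3cccc(Cl)c3)C2=O)cc1OC` gives 5100 nM
- compound 3 `COc1ccc(/C=C2\CCC/C(=C\c3ccc(Cl)cc3)C2=O)cc1OC` gives 5900 nM

Compound 3 (5900 nM) stands within the scatter of compound 2, while compound 1 (16800 nM) has a higher number, beyond the scatter from compound 3.

Next in the series is compound 4 `COc1cccc(/C=C2\CCC/C(=C\c3ccc(OC)c(OC)c3)C2=O)c1`, not yet measured. Against compound 3 it carries 3-methoxyphenyl in place of 4-chlorophenyl on a double-bonded chain carbon bound to a double-bonded ring carbon.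

Going by the values given here, one measured step bears on this place (a 1.2-fold higher number from compound 2 to compound 3 (0.06 log units; within the scatter)). It exchanges 3-chlorophenyl for 4-chlorophenyl and stays within the scatter, so the number has not yet responded to a change at this place. Among the compounds with values here, that evidence is thin, as no measured compound shows the exchange of 4-chlorophenyl for 3-methoxyphenyl. Compound 1 differs from compound 3 in more than one place, so its value cannot be assigned to any single change.

In this assay no step beyond the scatter is therefore expected, and no direction is favoured. The step expected is a 1.1-fold higher number from compound 3 to compound 4 (0.04 log units; within the scatter) (an estimate, within the scatter). The estimated value for compound 4 is 6500 nM (expected range 2600 nM to 16000 nM).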

Compound 4, half-maximal inhibitory concentration: 3700 nM
Beside the measured number, compound 4's estimate is 1.8-fold (0.24 log units) above it; low and high end bracket the measured number.
By their numbers in this assay, from the lowest: compounds 4, 2 and 3 (each within the scatter of the next); then compound 1.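

In this assay, the place on a double-bonded chain carbon bound to a double-bonded ring carbon has now taken a change of substituent type, not only a shift of the chlorine: 3-methoxyphenyl in place of 4-chlorophenyl gives a 1.6-fold lower number from compound 3 to compound 4 (0.20 log units; within the scatter). This exchange brings in 1 hydrogen-bond acceptor where the leaving group has 0, and the number still does not respond beyond the scatter. The more direct exchange of methoxy in place of chloro on an aromatic carbon gives a 1.4-fold lower number from compound 2 to compound 4 (0.14 log units; within the scatter), so both exchanges read the same way, and no measurement offered here accounts for that outcome.

As far as these compounds go, all three groups compared at this place are phenyl rings with a single chloro or methoxy substituent, and none of them has yet produced a step beyond the scatter, so what would move the number here remains unknown. Still open, from the compounds shown here alone, is whether an amine or a carboxylic acid on this ring, or an ethoxy or longer alkoxy chain in place of methoxy, would give such a step, and in which direction.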